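The source may hold more compounds than are shown below. What is called first, only, known or untested is meant among the compounds shown, and "the series" means these compounds.

Working notes on the series. Compound 1 `COc1cc(-c2cc(/C=C/C(=O)c3ccc(N)cc3)[nH]n2)cc(OC)c1OC` and compound 2 `COc1ccc(-c2cc(/C=C/C(=O)c3ccc(N)cc3)[nH]n2)cc1OC` share one core; compound 3 `COc1cc(C(=O)/C=C/c2cc(-c3cc(OC)c(OC)c(OC)c3)n[nH]2)cc(OC)c1OC` and compound 4 `COc1ccc(-c2cc(/C=C/C(=O)c3cc(OC)c(OC)c(OC)c3)[nH]n2)cc1OC` share another. The difference between the two cores is not broken down here.

In a functional assay on MCF7 cells (Homo sapiens) for cytotoxicity, read by sulforhodamine B assay, with a stated time of 48 h, tested at 10 uM (on this read-out lower numbers stand for a stronger effect and higher numbers for a weaker effect at the one concentration tested), compound 1 gives -24% and compound 2 gives -6%. The change between the two is hydrogen in place of methoxy on an aromatic carbon, and it produces a number 18 percentage points higher from compound 1 to compound 2 (beyond the scatter). Compound 3 gives -85%, the lowest number of the three measured compounds; both compound 1 and compound 2 lie well above it, in each case beyond the scatter.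

Compound 4 has not been measured in this assay. It carries the same change relative to compound 3 that compound 2 carries relative to compound 1: hydrogen in place of methoxy on an aromatic carbon. The surroundings of the place read the same for both pairs, so this is the same change, made twice among the compounds shown. Among the measured compounds shown here, because the one measured instance is a number 18 percentage points higher from compound 1 to compound 2 (beyond the scatter), a step of similar size is expected on the core of compound 3, with the caveat that the step has been seen on a single core only and compound 3 starts from a much lower number. The step from compound 3 to compound 4 is therefore expected to be a number 20 percentage points higher from compound 3 to compound 4 (beyond the scatter). On that basis compound 4 is estimated at -65%, with an expected range from -85% to -40%.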

Compound 4, a percentage reported as activity, at one concentration (the size of the read-out at that concentration, not a potency): -81%
Compound 4: middle estimate off by 16 percentage points, on the high side; the range from low to high includes it.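

In this assay, hydrogen in place of methoxy on the core of compound 3 gives a number 4 percentage points higher from compound 3 to compound 4 (within the scatter), so on this core the change has no effect that can be told from the scatter, whereas the earlier step on the core of compound 1 lies beyond it. Set side by side, the two steps still cannot be told apart, and the data give no ground for saying that the core alters the outcome of this change: the same change on two cores in this assay, a number 18 percentage points higher (beyond the scatter) from compound 1 to compound 2 and a number 4 percentage points higher (within the scatter) from compound 3 to compound 4, 14 percentage points apart, within the scatter of two such steps. This does not show that the change carries over with a fixed size, nor that its effect depends on the core; two pairs, each read at a single concentration, cannot separate those two readings, and any rule for carrying the change to a further core would go beyond them.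

The compounds shown hold only methoxy or hydrogen at this place, so the outcome with a hydroxy group, a fluorine atom, an amine or a longer chain such as ethoxy there remains open. Also open, as far as these compounds go, is how the same change behaves on a third core, and whether a reading across several concentrations would separate the two steps.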